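Trimming an oxolane ring to a methyl on the shared core

A few compounds are considered here, and "the series" means these few. Any claim that something is new, unique, unknown or untested is made for them only; others in the source may bear on it.

Measured compounds:
- Compound 1, `Cc1cc(C)c(CN2CCc3c(Cl)cc([C@@H](CO)[C@@H]4CCOC4)c(Cl)c3C2=O)c(=O)[nH]1`: 2
- Compound 2, `COC(c1cc(Cl)c2c(c1Cl)C(=O)N(Cc1c(C)cc(C)[nH]c1=O)CC2)C1CCN(C(C)=O)CC1`: 2.9; 2.9 (2 entries)
- Compound 3, `COc1cc(C)[nH]c(=O)c1CN1CCc2c(Cl)cc([C@@H](O)C3COC3)c(Cl)c2C1=O`: 1.3

In a physicochemical assay for lipophilicity, at pH 7.4 (a lower number here means a more polar compound, a higher number a more lipophilic compound), compound 1 gives 2, the highest of the two single numbers shown. Its nearest neighbour is compound 3, whose value of 1.3 lies lower by a margin that is beyond the usual scatter. Compound 2 carries two entries in this assay rather than a single number, so it stands aside from this comparison.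

Compound 4, `Cc1cc(C)c(CN2CCc3c(Cl)cc([C@H](C)CO)c(Cl)c3C2=O)c(=O)[nH]1`, has not yet been measured. Compared with compound 1 it differs by methyl in place of oxolan-3-yl on a saturated chain carbon bound to an aromatic carbon and a saturated chain carbon. For the measured compounds named here, no measured pair in this set shows exactly this exchange, so the step has to be judged from the change itself. A small downward step in this assay is expected for compound 4, likely within the scatter of repeated measurements, since a five-heavy-atom ring gives way to a single carbon. The step from compound 1 to compound 4 is estimated as a number 0.20 log units lower from compound 1 to compound 4 (within the scatter). Compound 4 is therefore expected to give about 1.8, between 1.3 and 2.4.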

Compound 4, distribution coefficient: 2.6
Estimate against measurement, compound 4: 0.80 log units below; measured number outside the range, above it.
By their numbers in this assay, from the lowest: compound 3; then compound 1; then compound 4.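

For the compounds shown here, replacing oxolan-3-yl with methyl on a saturated chain carbon bound to an aromatic carbon and a saturated chain carbon gives the first single-place step in this set: the reading in this assay comes out a number 0.60 log units higher from compound 1 to compound 4 (beyond the scatter), so this position is not silent in this assay. The earlier compounds shown here could not show this, since they differ from one another in more than one place. Nothing measured here bears on the reason for the step.

On these data alone, whether a cyclopentyl ring, which would keep the ring but lose its oxygen, reads closer to compound 1 or to compound 4 stays open. So does the effect on this assay of an ethyl chain, an amine or a carboxylic acid at this same place.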